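Acetylation of the ring amine in the fluorophenylpyridine series

The source may report more compounds than this note shows. Statements on the series, on what has been measured and on what is new or still open speak of the compounds shown alone.

Measured compounds in an assay on cell membranes for displacement of a labelled ligand from proteinase-activated receptor 1 (Homo sapiens), read by scintillation counting, with a stated time of 60 min; on this read-out lower numbers stand for stronger inhibition and higher numbers for weaker inhibition:
compound 1 `COC1C[C@@H]2CCCC[C@@H]2[C@H]1/C=C/c1ccc(-c2cccc(F)c2)cn1`, 67 nM
compound 2 `CS(=O)(=O)OC1C[C@@H]2CCCC[C@@H]2[C@H]1/C=C/c1ccc(-c2cccc(F)c2)cn1`, 6.4 nM
compound 3 `NC1C[C@@H]2CCCC[C@@H]2[C@H]1/C=C/c1ccc(-c2cccc(F)c2)cn1`, 230 nM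

Compound 3 gives the highest number of the three; its nearest neighbour is compound 1, and compound 2 lies furthest away, both gaps beyond the scatter (a 3.4-fold higher number from compound 1 to compound 3 (0.54 log units; beyond the scatter), a 36-fold higher number from compound 2 to compound 3 (1.56 log units; beyond the scatter)). Compound 4 `CC(=O)NC1C[C@@H]2CCCC[C@@H]2[C@H]1/C=C/c1ccc(-c2cccc(F)c2)cn1` differs from compound 3 by acetyl in place of hydrogen on an amine nitrogen, that is, amino to acetamido. Among the compounds with values here, no measured step places an acetyl on a nitrogen, so the closest guide is the step at the corresponding oxygen, where a methylsulfonyl brought a 10-fold lower number from compound 1 to compound 2 (1.02 log units; beyond the scatter). Both steps add a group carrying a hydrogen-bond acceptor to the substituent on the saturated ring carbon, and the unsubstituted amine is the weakest point of the set. A lower number is therefore expected for compound 4 in this assay, with a step of about a 4.6-fold lower number from compound 3 to compound 4 (0.66 log units; beyond the scatter), smaller than the oxygen case since the starting group differs. Compound 4 is estimated at 50 nM, within 12 nM to 200 nM.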

Compound 4, half-maximal inhibitory concentration: 53 nM
For compound 4 the middle estimate is 1.1-fold (0.03 log units) below the measured one; low and high end bracket the measured number.
By their numbers in this assay, from the lowest: compound 2; then compounds 4 and 1 (each within the scatter of the next); then compound 3.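

In this assay, acetyl on the amine nitrogen gives a 4.3-fold lower number from compound 3 to compound 4 (0.64 log units; beyond the scatter), so the free amine is not required at this saturated ring carbon and its nitrogen accepts an acyl substituent. Acetamido and methoxy cannot be separated here, with a 1.3-fold lower number from compound 1 to compound 4 (0.10 log units; within the scatter), while the (methylsulfonyl)oxy group keeps a clear lead over acetamido, with an 8.3-fold higher number from compound 2 to compound 4 (0.92 log units; beyond the scatter). No measurement shown explains this ranking of the substituents.

From the compounds shown here alone, whether methylsulfonyl on the amine nitrogen, giving a methanesulfonamide, would reach the level of compound 2 remains open. Also open, going by these compounds, are the effects of a longer acyl chain or a carboxylic acid on this carbon, and of the configuration at this carbon, which the structures leave unspecified.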